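This account rests on a few compounds, and the source may have more. Where it says the series, first, only, none or still open, it means among the compounds named here.

Measured by an ADME assay for permeability, using PAMPA, with a stated time of 30 min, at pH 7.4 (on this read-out lower numbers stand for lower permeability and higher numbers for higher permeability), and with the shared core in common, compound 1 (`CN(C)c1cccc(Oc2ccc3c(NCCCNCc4ccco4)ccnc3c2)c1`) gives 317 10^-6 cm/s and compound 2 (`c1ccc(Oc2ccc3c(NCCCNCc4ccco4)ccnc3c2)cc1`) gives 317 10^-6 cm/s, while compound 3 (`COc1ccc(-c2ccc3c(NCCCNCc4ccco4)ccnc3c2)cc1`) gives 237 10^-6 cm/s on the same scale. Compound 3 thus stands within the usual scatter of the other two. Compound 4 (`c1coc(CNCCCNc2ccnc3cc(CC4CCCCC4)ccc23)c1`) has not yet been measured. It carries cyclohexylmethyl in place of 4-methoxyphenyl on an aromatic carbon. Two measured steps also change the group at that place, and a 1.3-fold lower number from compound 1 to compound 3 (0.13 log units; within the scatter) and a 1.3-fold lower number from compound 2 to compound 3 (0.13 log units; within the scatter) both stay within the scatter. Hydrogen in place of dimethylamino gives no change at the digits printed from compound 1 to compound 2 (within the scatter) and adds nothing larger. None of these compounds puts a non-aromatic ring at that place, so the evidence is indirect and the range must stay wide. No step beyond the scatter is expected in this assay, and the estimated step is a 1.1-fold higher number from compound 3 to compound 4 (0.06 log units; within the scatter) within that scatter. For compound 4 the estimated value is 270 10^-6 cm/s with an expected range from 140 10^-6 cm/s to 500 10^-6 cm/s on this scale.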

Compound 4, apparent permeability: 23 10^-6 cm/s
For compound 4 the middle estimate is 12-fold (1.07 log units) above the measured one; measured number below the stated range.
By their numbers in this assay, from the lowest: compound 4; then compounds 3, 1 and 2 (each within the scatter of the next).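

In this assay this position proves sensitive to what it carries: 4-methoxyphenyl, phenoxy and 3-(dimethylamino)phenoxy all lie within the scatter of one another, yet cyclohexylmethyl gives a 10-fold lower number from compound 3 to compound 4 (1.01 log units; beyond the scatter) and a 14-fold lower number from compound 2 to compound 4 (1.14 log units; beyond the scatter) and a 14-fold lower number from compound 1 to compound 4 (1.14 log units; beyond the scatter). The change replaces a six-membered aromatic ring of carbon only with a six-membered non-aromatic ring of carbon only, and it also removes the hydrogen-bond acceptor of 4-methoxyphenyl, so several differences arrive together in one step. Nothing measured here accounts for the drop.

The compounds shown leave open whether the drop follows the non-aromatic ring or its carbon link, which benzyl or a directly attached cyclohexyl could separate. They also leave open how a ring carrying an amine, such as piperidin-4-ylmethyl, would read at this position.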